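Triazine anilines: cytotoxicity before the third aniline is added

This account rests on a few compounds, and the source may have more. Where it says the series, first, only, none or still open, it means among the compounds named here.

Compound 1 `Cc1ccc(Nc2nc(NCC3CCCO3)nc(Nc3ccc(C)cc3)n2)cc1` — > 50000 nM; > 50000 nM; > 50000 nM; > 50000 nM (4 entries)
Compound 2 `Cc1ccc(Nc2nc(O)nc(Nc3ccc(C)cc3)n2)cc1` — > 12500 nM

In an ADME assay on U2OS cells (Homo sapiens) for cytotoxicity, with a stated time of 48 h (on this read-out higher numbers stand for lower toxicity in this test and lower numbers for higher toxicity in this test), compound 1 gives > 50000 nM; > 50000 nM; > 50000 nM; > 50000 nM (4 entries). In this assay compound 2 gives > 12500 nM, which is a limit of the assay and not a number. Compound 2 therefore stands only at the edge of what this assay could see, a position marked by the limit of > 12500 nM in this assay, at which 1 of the 2 values shown sits. Going by the values given here, the two measured compounds differ in one place, yet no measured step between them is given, so nothing can be said about the size of that step.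

Compound 3 `Cc1ccc(Nc2nc(Nc3ccc(C)cc3)nc(Nc3ccc(C)cc3)n2)cc1` has not been measured. It differs from compound 2 by (4-methylphenyl)amino in place of hydroxy on an aromatic carbon. With compound 2 sitting at a limit, the step from compound 2 to compound 3 is expected to be none beyond the scatter, as a step that the limit leaves unreadable from compound 2 to compound 3. For compound 3 in this assay the estimated half-maximal cytotoxic concentration is 30000 nM, with a range from 5000 nM to 100000 nM.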

Compound 3, half-maximal cytotoxic concentration: > 50000 nM
Compound 3: only a limit was reported (the forecaster's own chance of this, stated with the estimate: 60%); at least 1.6-fold (0.22 log units) between middle value and limit.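

The results for compound 2 and compound 3 in this assay are both limits of the assay and not numbers, and the step between these two compounds cannot be read. The compounds shown leave open whether (4-methylphenyl)amino in place of hydroxy on an aromatic carbon changes the result in this assay at all, and at what concentration either compound would harm the cells.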